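The source may report more compounds than this note shows. Statements on the series, on what has been measured and on what is new or still open speak of the compounds shown alone.

Compound 1 `CCCn1c(CN2CCN(c3nc(Cl)ccc3C(F)(F)F)CC2)nc2ccccc21` gives the highest of the three numbers measured in an assay on CHO cells with metabotropic glutamate receptor 2 (Homo sapiens) as the target, read by FLIPR (a higher number here means that more compound is needed for the effect, a lower number that less compound is needed), namely 2510 nM. Compound 2 `Cn1c(CN2CCN(c3nc4ccccc4s3)CC2)nc2ccccc21` gives 316 nM in this assay, a lower number that lies beyond the scatter, and compound 3 `CCn1c(CN2CCN(c3ncc(Cl)cn3)CC2)nc2ccccc21` gives 158 nM, also beyond the scatter from compound 1. Compound 4 `FC(F)(F)c1ccc(Cl)nc1N1CCN(Cc2nc3ccccc3[nH]2)CC1` differs from compound 1 by hydrogen in place of propyl on an aromatic nitrogen. For the measured compounds named here, no pair of measured compounds isolates this change; compound 2 and compound 3 differ from compound 1 in more than one place, so their values show no step for it. The step from compound 1 to compound 4 is therefore expected to be a 1.0-fold lower number from compound 1 to compound 4 (0.00 log units; within the scatter), not beyond the scatter in either direction. Compound 4 is estimated at about 2500 nM, within 600 nM to 10000 nM.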

Compound 4, half-maximal effective concentration: 12600 nM
Estimate against measurement, compound 4: 5.0-fold (0.70 log units) below; measured number above the stated range.
By their numbers in this assay, from the lowest: compounds 3 and 2 (each within the scatter of the next); then compound 1; then compound 4.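

In this assay, hydrogen in place of propyl on this aromatic nitrogen gives a 5.0-fold higher number from compound 1 to compound 4 (0.70 log units; beyond the scatter) and so is not a neutral change. For the compounds shown here, this is the first step isolated at this position, and it shows that the propyl of compound 1 goes with a lower number than hydrogen on the same core. Nothing available gives a measured reason for this step. The compounds shown leave open whether a butyl chain or a benzyl group on this nitrogen would lower the number further. They also leave open whether the step keeps its size with the other end groups seen in compound 2 and compound 3.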